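Arylpiperazine in Place of Cyclohexylpiperazine on the Shared Core

The compounds below may be only part of what the source reports. "The series", "measured", "known", "first", "only" and "open" are said of these compounds alone.

Of the compounds shown here, two have been measured so far. Compound 1 `CC(C(=O)NCc1ccc(C(F)(F)F)cc1N1CCCCCC1)c1ccc(NS(C)(=O)=O)c(F)c1` gives 1.6 nM in an assay on CHO cells for antagonist activity at transient receptor potential cation channel subfamily V member 1 (Homo sapiens), read by FLIPR; on this read-out lower numbers stand for stronger inhibition and higher numbers for weaker inhibition. Compound 2 `CC(C(=O)NCc1ccc(C(F)(F)F)cc1N1CCN(C2CCCCC2)CC1)c1ccc(NS(C)(=O)=O)c(F)c1` gives 13.8 nM in the same assay, the higher of the two numbers; the step of an 8.6-fold higher number from compound 1 to compound 2 (0.94 log units; beyond the scatter) lies beyond the scatter. Compound 3 `COc1ccc(N2CCN(c3cc(C(F)(F)F)ccc3CNC(=O)C(C)c3ccc(NS(C)(=O)=O)c(F)c3)CC2)cc1` has not yet been measured. It differs from compound 2 in one place: 4-methoxyphenyl in place of cyclohexyl on an amine nitrogen in a ring. Going by the values given here, no measured step touches the group on that ring nitrogen, so the only bearing precedent is the single step from compound 1 to compound 2, which concerns a different position and gives no guidance on the direction here. The change is therefore expected to produce a step of a 1.4-fold higher number from compound 2 to compound 3 (0.16 log units; within the scatter) that stays near the scatter, with a wide range either way. For compound 3 the expected value in this assay is 20 nM, estimated to lie between 5 nM and 80 nM.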

Compound 3, inhibition constant: 1.6 nM
Beside the measured number, compound 3's estimate is 13-fold (1.10 log units) above it; the whole stated range lies above it.
By their numbers in this assay, from the lowest: compounds 1 and 3 (each within the scatter of the next); then compound 2.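

The group on the amine nitrogen in the ring clearly matters: in this assay, 4-methoxyphenyl in place of cyclohexyl gives an 8.6-fold lower number from compound 2 to compound 3 (0.94 log units; beyond the scatter). The higher number of compound 2 is therefore not shared by every compound carrying this ring, since compound 3 keeps the ring and reads 1.6 nM, the same printed value as compound 1 at 1.6 nM. Nothing available here accounts for this difference between the two groups.

The compounds shown do not separate the contribution of the aromatic ring from that of its methoxy group, which a plain phenyl on the same nitrogen would address. Nor do they show how a benzyl group or a 4-chlorophenyl group would read at this position.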